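Cyclohexyl versus isopropyl on the amide, across two cores

This account rests on a few compounds, and the source may have more. Where it says the series, first, only, none or still open, it means among the compounds named here.

Measured so far in an assay for displacement of a labelled ligand from Sigma non-opioid intracellular receptor 1 (Cavia porcellus); a lower number here means a stronger inhibitor, a higher number a weaker inhibitor:
compound 1 `O=C(NC1CCCCC1)C1CCN(Cc2ccc(Cl)cc2)CC1` gives 7.7 nM
compound 2 `CC(C)NC(=O)C1CCN(Cc2ccc(Cl)cc2)CC1` gives 637 nM
compound 3 `O=C(NC1CCCCC1)C1CCN(Cc2ccccc2)CC1` gives 15 nM

The two cores differ by hydrogen in place of chloro on an aromatic carbon; that step reads a 1.9-fold higher number from compound 1 to compound 3 (0.29 log units; within the scatter). Compound 4 `CC(C)NC(=O)C1CCN(Cc2ccccc2)CC1` is not yet measured. It stands to compound 3 as compound 2 stands to compound 1: isopropyl in place of cyclohexyl on an amide-type nitrogen on one core and isopropyl in place of cyclohexyl on an amide-type nitrogen on the other, the place being the same in both, so the change occurs twice among these compounds. On the first core the step was an 83-fold higher number from compound 1 to compound 2 (1.92 log units; beyond the scatter). For the measured compounds named here, the step in this assay from compound 3 to compound 4 is expected to be of about the same size, an 80-fold higher number from compound 3 to compound 4 (1.90 log units; beyond the scatter), because the single measured instance reads an 83-fold higher number from compound 1 to compound 2 (1.92 log units; beyond the scatter). Compound 4 is therefore estimated at 1200 nM, with an expected range from 400 nM to 4000 nM.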

Compound 4, inhibition constant: 1070 nM
Beside the measured number, compound 4's estimate is 1.1-fold (0.05 log units) above it; measured number inside the range.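

In this assay, isopropyl in place of cyclohexyl on an amide-type nitrogen carries over from the core of compound 1 to the core of compound 3, with a 71-fold higher number from compound 3 to compound 4 (1.85 log units; beyond the scatter) agreeing with the earlier step: the same change on two cores in this assay, an 83-fold higher number (1.92 log units; beyond the scatter) from compound 1 to compound 2 and a 71-fold higher number (1.85 log units; beyond the scatter) from compound 3 to compound 4, 1.2-fold (0.06 log units) apart, within the scatter of two such steps. Hydrogen in place of chloro on an aromatic carbon also carries over from the cyclohexyl amides to the isopropyl amides, with a 1.7-fold higher number from compound 2 to compound 4 (0.23 log units; within the scatter) again agreeing with the earlier step: the same change on two cores in this assay, a 1.9-fold higher number (0.29 log units; within the scatter) from compound 1 to compound 3 and a 1.7-fold higher number (0.23 log units; within the scatter) from compound 2 to compound 4, 1.2-fold (0.06 log units) apart, within the scatter of two such steps. This rests on a single pair of cores and two amide groups, so it shows that the two changes combine consistently in these four compounds and does not show that they would on other cores.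

Still open, going by these compounds, is how a cyclopentyl or a longer chain such as n-butyl on the amide-type nitrogen would read in this assay. Also open, on these data alone, is whether the step on the amide would hold with fluoro or methoxy in place of chloro on the aromatic carbon.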